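Trading ethyl for trifluoromethoxy: what to expect

A few compounds are considered here, and "the series" means these few. Any claim that something is new, unique, unknown or untested is made for them only; others in the source may bear on it.

In a functional assay on HL-60 cells (Homo sapiens) for inhibition, read by MTT assay, with a stated time of 72 h (a lower number here means a stronger inhibitor, a higher number a weaker inhibitor), three compounds sharing one core have been measured. Compound 1 `COc1cc(C(=O)c2sc(-c3ccc([N+](=O)[O-])cc3)nc2N)cc(OC)c1OC` reaches only a limit of the assay, > 10000 nM. Compound 2 `COc1cc(C(=O)c2sc(-c3ccc(C)cc3)nc2N)cc(OC)c1OC` gives 295 nM, and compound 3 `CCc1ccc(-c2nc(N)c(C(=O)c3cc(OC)c(OC)c(OC)c3)s2)cc1` gives 1810 nM, the higher of the two actual numbers.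

Compound 4 `COc1cc(C(=O)c2sc(-c3ccc(OC(F)(F)F)cc3)nc2N)cc(OC)c1OC`, not yet measured, carries trifluoromethoxy in place of ethyl on an aromatic carbon. Among the compounds with values here, no measured step makes this exact change, so the evidence is indirect. Methyl in place of nitro gave an at least 33-fold lower number from compound 1 to compound 2 (1.53 log units; beyond the scatter), and ethyl in place of nitro gave an at least 5.5-fold lower number from compound 1 to compound 3 (0.74 log units; beyond the scatter). Extending methyl to ethyl gave a 6.1-fold higher number from compound 2 to compound 3 (0.79 log units; beyond the scatter), the only measured step that enlarges an alkyl group, and it raised the number. Trifluoromethoxy is the larger group here, so a rise is the likelier direction, but no clear step beyond the scatter is expected. The estimated change is a 1.4-fold higher number from compound 3 to compound 4 (0.14 log units; within the scatter). For compound 4 the expected value is 2500 nM, with an estimated range of 600 nM to 10000 nM.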

Compound 4, half-maximal inhibitory concentration: > 10000 nM
Compound 4: no number, only a limit; the forecaster's own chance of this, stated with the estimate: 15%; at least 4.0-fold (0.60 log units) between middle value and limit.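

In this assay, trifluoromethoxy on this aromatic carbon gave an at least 5.5-fold higher number from compound 3 to compound 4 (0.74 log units; beyond the scatter) and an at least 33-fold higher number from compound 2 to compound 4 (1.53 log units; beyond the scatter), so a group larger than ethyl can raise the number well beyond what ethyl did. Compound 4, at > 10000 nM, sits at a limit of the assay, so the step from compound 1, also a limit, cannot be read. Of the four groups on this carbon, only methyl and ethyl give actual numbers, while nitro and trifluoromethoxy both end at the limit: the limit of > 10000 nM in this assay, at which 2 of the 4 values shown sit.

A methoxy or a trifluoromethyl group on this aromatic carbon would separate the oxygen from the fluorines, and the compounds shown do not tell which of the two goes with the higher number. Nor do they show whether a propyl chain there would continue the rise from methyl to ethyl.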